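The compounds below may be only part of what the source reports. "The series", "measured", "known", "first", "only" and "open" are said of these compounds alone.

Measured compounds in a functional assay on BGC-823 cells (Homo sapiens) for antiproliferative activity, read by MTT assay, with a stated time of 24 h; a lower number here means a stronger inhibitor, a higher number a weaker inhibitor:
compound 1 `O=[N+]([O-])c1cccc(CSc2nnc(-c3ccc4c(c3)OCCO4)n2-c2ccccc2)c1` gives 30100 nM;
compound 2 `Cc1ccccc1CSc1nnc(-c2ccc3c(c2)OCCO3)n1-c1ccccc1` gives > 100000 nM, which is a limit of the assay and not a number.

Compound 2 thus stands at the limit of > 100000 nM in this assay, at which 1 of the 2 values shown sits, so only a limit is known for it. Compound 3 `Brc1ccc(CSc2nnc(-c3ccc4c(c3)OCCO4)n2-c2ccccc2)cc1` differs from compound 2 by 4-bromophenyl in place of 2-methylphenyl on a saturated chain carbon bound to a sulfur. For the measured compounds named here, the one measured step, an at least 3.3-fold higher number from compound 1 to compound 2 (0.52 log units; beyond the scatter), joins two other groups on the saturated chain carbon bound to a sulfur and does not include a 4-bromophenyl; it only shows that a swap at that carbon can move this assay by at least that much. Going by the values given here, no measured step bears directly on the change to compound 3. Compound 3 is expected to remain weak in this assay, the expected step being an at least 1.6-fold lower number from compound 2 to compound 3 (0.22 log units; that floor lies within the scatter). The estimate for compound 3 is 60000 nM, expected to fall between 20000 nM and 200000 nM.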

Compound 3, half-maximal inhibitory concentration: 33800 nM
For compound 3 the middle estimate is 1.8-fold (0.25 log units) above the measured one; the measured number falls inside the stated range.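

On the saturated chain carbon bound to a sulfur, 4-bromophenyl gives a measured number in this assay where 2-methylphenyl does not, with an at least 2.9-fold lower number from compound 2 to compound 3 (0.47 log units; beyond the scatter). Compound 2 gives > 100000 nM, which is a limit of the assay and not a number. The two groups with a measured number are not told apart, with a 1.1-fold higher number from compound 1 to compound 3 (0.05 log units; within the scatter), so this carbon tolerates both 3-nitrophenyl and 4-bromophenyl equally in this assay.

Going by these compounds, whether the gap to compound 2 follows from the methyl group itself or from its place on the ring stays open. Also open, on these data alone, is what an amine, a carboxylic acid or a longer chain at this carbon would give.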